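This account rests on a few compounds, and the source may have more. Where it says the series, first, only, none or still open, it means among the compounds named here.

In an ADME assay on BHK-21 cells (Mesocricetus auratus) for cytotoxicity, read by MTT assay, with a stated time of 72 h (a lower number here means that less compound is tolerated, a higher number that more compound is tolerated), compound 1 `Cc1ccc(NCc2cn(-c3ccccc3)nc2-c2ccccc2)cc1` gives > 100000 nM, which is a limit of the assay. Compound 2 `FC(F)(F)c1ccc(NCc2cn(-c3ccccc3)nc2-c2ccccc2)cc1` gives 37000 nM, the highest of the two actual numbers, and compound 3 `FC(F)(F)c1ccc(NCc2cn(-c3ccccc3)nc2-c2ccc(Cl)cc2)cc1` gives 17000 nM. Compound 4 `Clc1ccc(NCc2cn(-c3ccccc3)nc2-c2ccccc2)cc1` carries chloro in place of trifluoromethyl on an aromatic carbon, para to a large group (chloro in place of trifluoromethyl on an aromatic carbon). The closest measured change at that place is an at least 2.7-fold lower number from compound 1 to compound 2 (0.43 log units; beyond the scatter), with trifluoromethyl in place of methyl. Chloro also entered at a different place in a 2.2-fold lower number from compound 2 to compound 3 (0.34 log units; beyond the scatter). Given the modest size of an at least 2.7-fold lower number from compound 1 to compound 2 (0.43 log units; beyond the scatter), a small rise or none beyond the scatter is expected in this assay. The estimated change is a 1.2-fold higher number from compound 2 to compound 4 (0.09 log units; within the scatter). For compound 4 the expected value is 45000 nM, with an estimated range of 20000 nM to 100000 nM.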

Compound 4, half-maximal cytotoxic concentration: > 100000 nM
Compound 4: no number, only a limit; the forecaster's own chance of this, stated with the estimate: 15%; middle value at least 2.2-fold (0.34 log units) away from the limit.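

In this assay, chloro in place of trifluoromethyl on an aromatic carbon, para to a large group, gives an at least 2.7-fold higher number from compound 2 to compound 4 (0.43 log units; beyond the scatter), so the step seen earlier with methyl now recurs with a second replacing group. Of the three groups shown at this position with the core of compound 1, only trifluoromethyl gives a number rather than a limit. Methyl and chloro cannot be ordered, and the step between compound 1 and compound 4 cannot be read, because both values are limits: the limit of > 100000 nM in this assay, at which 2 of the 4 values shown sit.

Going by these compounds, what an amine or a carboxylic acid would give at this position stays open. On these data alone, whether chloro in place of trifluoromethyl gives a similar step with the core of compound 3 also stays open.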